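The compounds below may be only part of what the source reports. "The series", "measured", "known", "first", "only" and "open" are said of these compounds alone.

The compounds measured so far:

Compound 1, `CCCS(=O)(=O)N1CCCN(C(=O)CC)CC1`: in a functional assay on the whole organism with Mus musculus as the target (on this read-out lower numbers stand for an effect already at smaller amounts and higher numbers for an effect only at larger amounts of compound), compound 1 gives only a limit, > 10 mg/kg.
Compound 2, `CC(=O)N1CCN(S(=O)(=O)c2ccc(F)cc2)C1`: compound 2 gives 1 mg/kg.
Compound 3, `CCC(=O)N1CCN(C(C)=O)CC1`: compound 3 gives 10 mg/kg.

Among the two plain numbers, compound 3 stands highest; the nearest is compound 2, whose lower number lies beyond the scatter. Within the data shown here, no measured pair differs in just one place, so no step between measured compounds is known.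

Compound 4, `CCC(=O)N1CCN(C(=O)CC)CC1`, has yet to be measured. It differs from compound 3 thus: methyl in place of hydrogen on a saturated chain carbon bound to a carbonyl carbon. Without a measured step of this kind, the author expects no change beyond the scatter, a step of no change at the digits printed from compound 3 to compound 4 (within the scatter). Compound 4 is therefore estimated at 10 mg/kg, with a range from 3 mg/kg to 30 mg/kg.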

Compound 4, minimum effective dose: > 10 mg/kg
Compound 4: a limit, no number; the forecaster's own chance of this, stated with the estimate: 30%; the middle value sits exactly at the limit.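

In this assay, methyl in place of hydrogen on a saturated chain carbon bound to a carbonyl carbon, which turns acetyl into propanoyl, gives a number no lower from compound 3 to compound 4 (the limit leaves the size open). Among these compounds, this is the first step known at this position, and it shows that the added methyl brings no lower effective dose, though the size of the step cannot be read. The reading ends at a limit of the assay: the limit of > 10 mg/kg in this assay, at which 2 of the 4 values shown sit.

The compounds shown leave open how a longer chain or an amine at this place would read out. They also leave open whether the same change would give a similar step on the acetyl of compound 2.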